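Pyrrolidinyl to imidazolyl swap on two carbamate cores

This account rests on a few compounds, and the source may have more. Where it says the series, first, only, none or still open, it means among the compounds named here.

Compound 1 `COC(=O)N(C)C(C)C#CCN1CCCC1` and compound 2 `COC(=O)N(C)C(C)C#CCn1ccnc1` share a core; compound 3 `CCOC(=O)N(C)CC#CCN1CCCC1` and compound 4 `CCOC(=O)N(C)CC#CCn1ccnc1` share another, and the difference between the two cores is not broken down here. In a functional assay on the whole organism for agonist activity, with Mus musculus as the target (on this read-out lower numbers stand for an effect already at smaller amounts and higher numbers for an effect only at larger amounts of compound), compound 1 gives 20.9 mg/kg and compound 2 gives 8 mg/kg, a step of a 2.6-fold lower number from compound 1 to compound 2 (0.42 log units; beyond the scatter) for the change (1H-imidazol-1-yl in place of pyrrolidin-1-yl on a saturated chain carbon bound to a triple-bonded carbon). For compound 3 only a limit, > 100 mg/kg, is recorded in this assay, as noted in the limit of > 100 mg/kg in this assay, at which 1 of the 3 values shown sits. The same change, (1H-imidazol-1-yl in place of pyrrolidin-1-yl on a saturated chain carbon bound to a triple-bonded carbon), carries compound 3 to compound 4. Within the data shown here, the step from compound 3 to compound 4 is expected at an at least 1.6-fold lower number from compound 3 to compound 4 (0.22 log units; that floor lies within the scatter), resting on the one earlier step of a 2.6-fold lower number from compound 1 to compound 2 (0.42 log units; beyond the scatter), and compound 4 is estimated at 60 mg/kg in this assay, between 20 mg/kg and 150 mg/kg.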

Compound 4, dose for half-maximal effect: > 100 mg/kg
Compound 4: a limit, no number (the forecaster's own chance of this, stated with the estimate: 40%); at least 1.6-fold (0.22 log units) between middle value and limit.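

Compound 3 and compound 4 both stand at a limit, so no step can be read from one to the other: the limit of > 100 mg/kg in this assay, at which 2 of the 4 values shown sit.
On these data alone, whether 1H-imidazol-1-yl in place of pyrrolidin-1-yl shifts the read-out on the core of compound 3 at all stays open.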